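The source may report more compounds than this note shows. Statements on the series, on what has been measured and on what is new or still open speak of the compounds shown alone.

Measured compounds:
Compound 1 `CCOC(=O)c1sc(-c2cccc(NC(=O)[C@H]3CC[C@H](C)CC3)c2)nc1Nc1ccc(N2CCN(C)CC2)cc1`: 19.9%
Compound 2 `CN1CCN(c2ccc(Nc3nc(-c4cccc(NC(=O)c5ccc(C(F)(F)F)cn5)c4)sc3C(N)=O)cc2)CC1`: 96.6%

Two compounds have numbers in a functional assay on Ramos cells (Homo sapiens) for antiproliferative activity, read by CCK-8 assay, with a stated time of 72 h, tested at 40 uM; a higher number here means more inhibition at the concentration tested (going by the name of the read-out), a lower number less inhibition. In this assay compound 2 gives 96.6%, the higher of the two, and compound 1 gives 19.9%, a result that falls beyond the usual scatter below it. Going by the values given here, no pair of these two differs in a single place, so the gap between them cannot be assigned to one change.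

The account now follows a step from compound 2 to compound 3 `CN1CCN(c2ccc(Nc3nc(-c4cccc(NC(=O)[C@H]5CC[C@H](C)CC5)c4)sc3C(N)=O)cc2)CC1`, which is not yet measured in this assay. The change is 4-methylcyclohexyl in place of 5-(trifluoromethyl)pyridin-2-yl on a carbonyl carbon. Compound 1 already carries the 4-methylcyclohexyl group that enters here, though it differs from compound 3 in another place, and its low reading in this assay is the only hint available. On that basis a drop beyond the scatter from compound 2 is expected, though its size is uncertain because compound 1 shows 19.9% while differing in more than this one place. The expected step is a number 41.6 percentage points lower from compound 2 to compound 3 (beyond the scatter). For compound 3 the estimate in this assay is 55%, within a range from 20% to 90%.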

Compound 3, a percentage reported as inhibition, at one concentration (the size of the read-out at that concentration, not a potency): 55.1%
For compound 3 the middle estimate is 0.1 percentage points below the measured one; low and high end bracket the measured number.
By their numbers in this assay, from the lowest: compound 1; then compound 3; then compound 2.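

In this assay, compound 3 shows that the group on the amide carbonyl carbon matters with the rest of the structure held fixed: 4-methylcyclohexyl in place of 5-(trifluoromethyl)pyridin-2-yl gives a number 41.5 percentage points lower from compound 2 to compound 3 (beyond the scatter). Compound 3 also links the two earlier compounds through single changes, since amino in place of ethoxy on a carbonyl carbon gives a number 35.2 percentage points higher from compound 1 to compound 3 (beyond the scatter), so the gap that could not be assigned to one change now runs through two large steps, each beyond the scatter. Nothing measured here explains why either change has the effect it does.

As far as these compounds go, each change is seen only once and against one partner group, so it remains open whether amino in place of ethoxy would give a similar step in a compound carrying 5-(trifluoromethyl)pyridin-2-yl. From the compounds shown here alone, it is also open how a plain phenyl or a pyridin-2-yl without the trifluoromethyl would read on the amide carbonyl carbon, and how a methylamino group would read in place of the amino group.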